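The source may report more compounds than this note shows. Statements on the series, on what has been measured and on what is new or still open speak of the compounds shown alone.

In a physicochemical assay for acid dissociation, compound 2 `CS(=O)(=O)c1ccc(O)c(C(=O)Nc2ccc(C(F)(F)F)cc2)c1` gives 6.2. Compound 1 `CCCCCCCCCCCCS(=O)(=O)c1ccc(O)c(C(=O)Nc2ccc(C(F)(F)F)cc2)c1`, which carries a far longer chain on the sulfonyl sulfur, gives 6.2, so compound 2 stands level with compound 1. Still unmeasured is compound 3 `CCCCCCCCCCS(=O)(=O)c1ccc(O)c(C(=O)Nc2ccc(C(F)(F)F)cc2)c1`. Its difference from compound 2 is nonyl in place of hydrogen on a saturated chain carbon bound to a sulfonyl sulfur, which can also be read as methyl to decyl. Among the measured compounds shown here, only one measured step bears on this change: no change at the digits printed from compound 1 to compound 2 (within the scatter), where hydrogen replaces undecyl at that same place. That step lies within the scatter, and it is a single pair, so the evidence is thin. The new change runs the opposite way, from hydrogen to a long chain. In this assay the expected step is no change at the digits printed from compound 2 to compound 3 (within the scatter), with no direction expected beyond the scatter. The estimated value for compound 3 is 6.2, with an expected range from 5.9 to 6.5.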

Compound 3, acid dissociation constant: 6.2
For compound 3 middle estimate and measured number coincide at the digits printed; the range from low to high includes it.
By their numbers in this assay, from the lowest: compounds 1, 2 and 3 (each within the scatter of the next).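

In this assay, putting nonyl in place of hydrogen on a saturated chain carbon bound to a sulfonyl sulfur gives no change at the digits printed from compound 2 to compound 3 (within the scatter) and so shows that lengthening the chain at this place matches the earlier result from shortening it. Hydrogen in place of ethyl on a saturated chain carbon gives no change at the digits printed from compound 1 to compound 3 (within the scatter) and adds a second comparison among the long chains, leaving compounds 1, 2 and 3 level in this read-out. No measurement shown here explains why these numbers stand level.

From the compounds shown here alone, whether a chain ending in an amine or a carboxylic acid would stay level at this place remains open. So does whether a phenyl ring on the sulfonyl sulfur would do so.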